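Bromo for Ethyl on the Cinnamamide Aryl Ring

A few compounds are considered here, and "the series" means these few. Any claim that something is new, unique, unknown or untested is made for them only; others in the source may bear on it.

Compound 2 `CCCc1cc(N)c2cc(NC(=O)/C=C/c3ccc(CC)cc3)ccc2n1` carries a free amino group on the shared core and an ethyl group on the cinnamamide aryl ring. Going by the values given here, in a functional assay on HEK293 cells for activation of melanin-concentrating hormone receptor 1 (Homo sapiens), read by inositol phosphate accumulation (on this read-out higher numbers stand for an effect only at larger amounts of compound and lower numbers for an effect already at smaller amounts), compound 2 gives 160 nM, the lowest of the three numbers measured so far. Compound 1 `CCCc1cc(NC2CCC2)c2cc(NC(=O)/C=C/c3ccc(C(F)(F)F)cc3)ccc2n1` gives 270 nM in this assay, a number within the scatter of compound 2. Compound 3 `CCCc1cc(N2CCCC2)c2cc(NC(=O)/C=C/c3ccc(C(F)(F)F)cc3)ccc2n1` gives 2800 nM in this assay, and the single-point step a 10-fold higher number from compound 1 to compound 3 (1.02 log units; beyond the scatter) is the only one measured among these compounds.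

Compound 4 `CCCc1cc(N)c2cc(NC(=O)/C=C/c3ccc(Br)cc3)ccc2n1` differs from compound 2 in one place: bromo in place of ethyl on an aromatic carbon. Among the compounds with values here, the one measured step concerns the amino substituent on the core, not the aryl ring of the cinnamamide, so it does not bear on this change. Within the data shown here, compound 1 and compound 2 differ at two places at once, and their values show only that two compounds with different aryl substituents and different core amines lie within the scatter of one another. Among the measured compounds shown here, no measured step therefore speaks to a change at this position, and the expectation is a step no larger than the scatter, in no particular direction.

Compound 4 is thus estimated at 200 nM in this assay, with a range from 70 nM to 600 nM. The expected step is a 1.3-fold higher number from compound 2 to compound 4 (0.10 log units; within the scatter).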

Compound 4, half-maximal effective concentration: 93 nM
For compound 4 the middle estimate is 2.2-fold (0.33 log units) above the measured one; the range from low to high includes it.
By their numbers in this assay, from the lowest: compounds 4, 2 and 1 (each within the scatter of the next, the first and the last beyond it); then compound 3.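

Going by these compounds alone, the step of a 1.7-fold lower number from compound 2 to compound 4 (0.24 log units; within the scatter) is the first measured change on the cinnamamide aryl ring with the rest of the molecule held fixed, and in this assay it gives a first direct reading at this position. With a free amino group on the shared core, the 4-ethylphenyl and 4-bromophenyl compounds cannot be told apart, so this exchange on an aromatic carbon, para to a large group, does not move the number beyond the scatter, unlike the large step of a 10-fold higher number from compound 1 to compound 3 (1.02 log units; beyond the scatter) at the amine on the core. No measurement of any property of these groups is available to explain this result.

As far as these compounds go, whether ethyl and bromo would also stay within the scatter of each other with cyclobutylamino or pyrrolidin-1-yl on the core remains open, as those two compounds carry trifluoromethyl on the aryl ring. Also open, from the compounds shown here alone, is how this position would respond to a carboxylic acid, an amine or a longer chain such as butyl, so the present step describes only the exchange of ethyl and bromo.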